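The source may report more compounds than this note shows. Statements on the series, on what has been measured and on what is new or still open speak of the compounds shown alone.

Going by the values given here, compound 3, with the structure `CN(C)C(=O)c1cc2cnc(Nc3ccc(NC(=O)C4(C(=O)Nc5ccc(Cl)c(C(F)(F)F)c5)CC4)cc3)nc2n1C1CCCC1`, stands second highest of the three numbers so far in a functional assay on HeLa cells (Homo sapiens) for inhibition, read by CCK-8 assay, with a stated time of 72 h, tested at 10 uM (a higher number here means more inhibition of growth at the concentration tested, a lower number less inhibition of growth), where compound 3 gives 55.6%. Its nearest neighbour is compound 2, with the structure `CN(C)C(=O)c1cc2cnc(Nc3ccc(NC(=O)C4(C(=O)Nc5ccc(F)cc5)CC4)cc3F)nc2n1C1CCCC1`, which in this assay gives 49.5%, a difference that lies within the scatter. Its furthest neighbour is compound 1, with the structure `CN(C)C(=O)c1cc2cnc(Nc3ccc(NC(=O)C4(C(=O)Nc5cccc(O)c5)CC4)cc3)nc2n1C1CCCC1`, which in this assay gives 96.6%. Among the compounds with values here, the one step measured into compound 3 is a number 41 percentage points lower from compound 1 to compound 3 (beyond the scatter).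

The next compound, compound 4, has the structure `CN(C)C(=O)c1cc2cnc(Nc3ccc(NC(=O)C4(C(=O)Nc5ccc(O)cc5)CC4)cc3)nc2n1C1CCCC1`. The change from compound 3 is 4-hydroxyphenyl in place of 4-chloro-3-(trifluoromethyl)phenyl on an amide-type nitrogen. Within the data shown here, the single measured step that bears on it is the step from compound 1 to compound 3, which ran in the opposite sense, from a hydroxyphenyl to the 4-chloro-3-(trifluoromethyl)phenyl, and cost a large amount of growth inhibition; compound 4 reverses that exchange, though with the hydroxyl on the phenyl now placed as 4-hydroxyphenyl rather than 3-hydroxyphenyl. A step upward in this assay is therefore expected, most of it regained, with a number 32.4 percentage points higher from compound 3 to compound 4 (beyond the scatter) as the expected size. For compound 4 the expected value in this assay is 88%, within a range from 65% to 99%.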

Compound 4, percent growth inhibition at one concentration: 99.9%
Estimate against measurement, compound 4: 11.9 percentage points below, and the stated range ends below it.
By their numbers in this assay, from the lowest: compounds 2 and 3 (each within the scatter of the next); then compounds 1 and 4 (each within the scatter of the next).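

With a number 44.3 percentage points higher from compound 3 to compound 4 (beyond the scatter) in this assay, the exchange of 4-chloro-3-(trifluoromethyl)phenyl for 4-hydroxyphenyl on the amide-type nitrogen shows that the large difference seen earlier with 3-hydroxyphenyl is not confined to that one group: two different hydroxyphenyl groups now stand well apart from the 4-chloro-3-(trifluoromethyl)phenyl group. The comparison of the two hydroxyphenyl groups, a number 3.3 percentage points higher from compound 1 to compound 4 (within the scatter) in the same assay, lies within the scatter, so this single-concentration read-out does not separate 3-hydroxyphenyl from 4-hydroxyphenyl at this position. Nothing measured here explains either step, and the data give no reason for the difference between these groups.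

The compounds shown leave open whether the hydroxyl itself matters or whether other small groups on the phenyl, such as a methoxy, an amine or a carboxylic acid, or an unsubstituted phenyl, would give similar growth inhibition. Compound 2 differs from the others in more than one place, so its 4-fluorophenyl group cannot be judged on its own, and a single tested concentration leaves any potency difference between compound 1 and compound 4 unresolved.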